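Swapping a Fluorobenzyl Amide for an Anilide

This account rests on a few compounds, and the source may have more. Where it says the series, first, only, none or still open, it means among the compounds named here.

Compound 1 `CC1=C(/C=C/C(C)=C/C=C/C(C)=C\C(=O)NCc2ccc(F)cc2)C(C)(C)CCC1n1ccnc1` gives the lowest number of the three compounds tested in a functional assay on MCF7 cells (Homo sapiens) for inhibition, read by MTT assay (on this read-out higher numbers stand for weaker inhibition of growth and lower numbers for stronger inhibition of growth), at 1930 nM. Compound 3 `CC1=C(/C=C/C(C)=C/C=C/C(C)=C\C(=O)NCc2ccc(O)cc2)C(C)(C)CC=C1c1cncnc1` gives 4960 nM and compound 2 `CC1=C(/C=C/C(C)=C/C=C/C(C)=C\C(=O)Nc2ccccc2)C(C)(C)CC=C1c1cccnc1` gives 8320 nM, both beyond the scatter from compound 1, so compound 1 is the strongest growth inhibitor measured so far. Compound 4 `CC1=C(/C=C/C(C)=C/C=C/C(C)=C\C(=O)Nc2ccccc2)C(C)(C)CCC1n1ccnc1` has not yet been measured; it differs from compound 1 in one place: phenyl in place of 4-fluorobenzyl on an amide-type nitrogen. Going by the values given here, no measured pair isolates this change. Compound 2 also bears phenyl on its amide nitrogen but differs from compound 1 elsewhere too, so its value cannot be read as this change alone. A weakening of growth inhibition beyond the scatter is expected, as the step of a 2.3-fold higher number from compound 1 to compound 4 (0.37 log units; beyond the scatter). In this assay compound 4 is estimated at 4500 nM, with a range from 1500 nM to 13000 nM.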

Compound 4, concentration for 50% growth inhibition: 1900 nM
Compound 4: the middle estimate sits 2.4-fold (0.37 log units) above what was measured; the range from low to high includes it.
By their numbers in this assay, from the lowest: compounds 4 and 1 (each within the scatter of the next); then compounds 3 and 2 (each within the scatter of the next).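

In this assay the amide nitrogen takes phenyl as well as 4-fluorobenzyl, with a 1.0-fold lower number from compound 1 to compound 4 (0.01 log units; within the scatter) as the step. The fluorine and the carbon link of 4-fluorobenzyl can therefore go together without a change in growth inhibition at this position. No available data explain this match.

Whether the fluorine and the carbon link would each matter alone stays open, as plain benzyl and 4-fluorophenyl are not among the compounds shown. Also open, going by these compounds, is how a longer chain such as 2-phenylethyl would behave on this nitrogen.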